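Oxetan-2-yl in place of oxan-4-yl: working notes

A few compounds are considered here, and "the series" means these few. Any claim that something is new, unique, unknown or untested is made for them only; others in the source may bear on it.

Measured in an in vitro ADME assay on microsomes from liver (Homo sapiens) for metabolic stability, read by HPLC; on this read-out higher numbers stand for fast clearance and lower numbers for slow clearance:
- compound 1 `CC1(C)CO[C@H]1CN([C@H](CCC(F)(F)F)C(N)=O)S(=O)(=O)c1ccc(Cl)cc1`: 262 mL/min/kg
- compound 2 `NC(=O)[C@@H](CCC(F)(F)F)N(CC1CCOCC1)S(=O)(=O)c1ccc(Cl)cc1`: 114 mL/min/kg

Compound 2 holds the lower of the two numbers, at 114 mL/min/kg. Next is compound 3 `NC(=O)[C@@H](CCC(F)(F)F)N(C[C@H]1CCO1)S(=O)(=O)c1ccc(Cl)cc1`: oxetan-2-yl in place of oxan-4-yl on a saturated chain carbon bound to a sulfonamide nitrogen. Within the data shown here, the one measured step bearing on this change is a 2.3-fold lower number from compound 1 to compound 2 (0.36 log units; beyond the scatter), a modest one. Its group 3,3-dimethyloxetan-2-yl is not the oxetan-2-yl entering here, so it offers only weak guidance. In this assay the expected result is a 1.1-fold higher number from compound 2 to compound 3 (0.02 log units; within the scatter), with no step beyond the scatter anticipated. The estimate for compound 3 is 120 mL/min/kg, with a range of 55 mL/min/kg to 260 mL/min/kg.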

Compound 3, clearance: 63.8 mL/min/kg
Compound 3: the middle estimate sits 1.9-fold (0.27 log units) above what was measured; the measured number falls inside the stated range.
By their numbers in this assay, from the lowest: compounds 3 and 2 (each within the scatter of the next); then compound 1.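

In this assay the step to oxetan-2-yl on a saturated chain carbon bound to a sulfonamide nitrogen, a 1.8-fold lower number from compound 2 to compound 3 (0.25 log units; within the scatter), leaves the read-out level with the oxan-4-yl group. The second step, a 4.1-fold lower number from compound 1 to compound 3 (0.61 log units; beyond the scatter), shows that the high number of compound 1 does not go with the four-membered ring alone, since compound 3 carries that ring without the two methyl groups of 3,3-dimethyloxetan-2-yl. Nothing available gives a reason for either step.

Open, as far as these compounds go, is how a single methyl on oxetan-2-yl would read in this assay at this place. Also open, from the compounds shown here alone, is how an amine or a longer chain there would read.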